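The source may report more compounds than this note shows. Statements on the series, on what has been measured and on what is new or still open speak of the compounds shown alone.

Measured so far in an assay on CHO cells for displacement of a labelled ligand from 5-hydroxytryptamine receptor 1D (Homo sapiens); a lower number here means a stronger inhibitor, a higher number a weaker inhibitor:
compound 1 `O=S(=O)(NCC1CCN(CCCc2c[nH]c3ccc(-n4cnnc4)cc23)CC1)c1ccccc1` gives 6.2 nM;
compound 2 `CC(C)=CCCN(C)C1CCN(CCCc2c[nH]c3ccc(-n4cnnc4)cc23)CC1` gives 2.6 nM;
compound 3 `CN(CC1CCN(CCCc2c[nH]c3ccc(-n4cnnc4)cc23)CC1)C(=O)Nc1ccccc1` gives 5.9 nM.

Compound 1 has the highest of the three numbers. Its nearest neighbour is compound 3, within the scatter; the furthest is compound 2, beyond it.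

Compound 4 `CC(=O)Nc1ccc([C@@H](C)NCC2CCN(CCCc3c[nH]c4ccc(-n5cnnc5)cc34)CC2)cc1` has not been measured. It differs from compound 1 by 1-(4-acetamidophenyl)ethyl in place of phenylsulfonyl on an amine nitrogen.

Among the compounds with values here, two measured steps bear on this end of the molecule. a 1.1-fold lower number from compound 1 to compound 3 (0.02 log units; within the scatter) exchanged one group for another there and left the number essentially unchanged. a 2.4-fold lower number from compound 1 to compound 2 (0.38 log units; beyond the scatter) replaced the whole terminal group and gave a modest gain. Together they show that the number in this assay moves little when this part is altered, and where it moves, it moves downward.

For compound 4 a small drop in number is therefore expected, a 1.6-fold lower number from compound 1 to compound 4 (0.19 log units; within the scatter), at the edge of the scatter.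

Compound 4 is estimated at 4 nM, with a range from 1.5 nM to 11 nM.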

Compound 4, half-maximal inhibitory concentration: 1.5 nM
Compound 4: middle estimate off by 2.7-fold (0.43 log units), on the high side; the measured number falls inside the stated range.
By their numbers in this assay, from the lowest: compounds 4 and 2 (each within the scatter of the next); then compounds 3 and 1 (each within the scatter of the next).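

In this assay, 1-(4-acetamidophenyl)ethyl in place of phenylsulfonyl on the amine nitrogen gives a 4.1-fold lower number from compound 1 to compound 4 (0.62 log units; beyond the scatter), so the phenylsulfonyl group is not required at this position for a low number. This change also shows that a larger group with a defined stereocentre is accepted here, and the step lies beyond the scatter, unlike a 1.1-fold lower number from compound 1 to compound 3 (0.02 log units; within the scatter). No available evidence accounts for the size of this step.

The compounds shown do not separate the contributions of the acetamido group, the branching methyl of the ethyl linker and the loss of the sulfonyl group; a plain benzyl group, a 1-phenylethyl group or a 4-aminophenyl analogue would address this. Going by these compounds, the effect of the opposite configuration at the stereocentre also remains open.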